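This account rests on a few compounds, and the source may have more. Where it says the series, first, only, none or still open, it means among the compounds named here.

Four compounds share the same pattern of a methoxy-bearing aryl ketone carrying an amide side chain, and differ either in the core or in the amine at the end of that side chain. Compound 1 `CCNCC(=O)Nc1cc(OC)ccc1C(=O)c1ccc(OC)c2c1OC(C)(C)C=C2` and compound 2 `CCNCC(=O)Nc1cc(OC)ccc1C(=O)c1ccc2c(c1)C=CC(C)(C)O2` carry the ethylamino end; the difference between their two cores is not broken down here. In a functional assay on MCF7 cells (Homo sapiens) for antiproliferative activity, read by MTT assay, with a stated time of 48 h (a lower number here means a stronger inhibitor, a higher number a weaker inhibitor), compound 1 gives 5200 nM, and compound 2 gives 6310 nM; these two values lie within the usual scatter of each other.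

Compound 3 `COc1ccc(C(=O)c2ccc(OC)c3c2OC(C)(C)C=C3)c(NC(=O)CN(C)C)c1` has the core of compound 1 with dimethylamino in place of ethylamino on a saturated chain carbon bound to a carbonyl carbon. In this assay compound 3 gives 2680 nM, which is a 1.9-fold lower number from compound 1 to compound 3 (0.29 log units; within the scatter), a step that stays within the scatter.

Compound 4 `COc1ccc(C(=O)c2ccc3c(c2)C=CC(C)(C)O3)c(NC(=O)CN(C)C)c1` has the core of compound 2 with dimethylamino in place of ethylamino on a saturated chain carbon bound to a carbonyl carbon, the same change as that from compound 1 to compound 3. On the core of compound 1 that change gave a 1.9-fold lower number from compound 1 to compound 3 (0.29 log units; within the scatter); on the core of compound 2 a step of similar size is expected, because compound 2 gives 6310 nM and the two cores behave alike with the ethylamino end. Compound 4 is therefore estimated to give 3400 nM, with a likely range from 1500 nM to 8000 nM, which means an expected step of a 1.9-fold lower number from compound 2 to compound 4 (0.27 log units; within the scatter). This expectation rests on a single measured pair only.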

Compound 4, half-maximal inhibitory concentration: 3560 nM
Beside the measured number, compound 4's estimate is 1.0-fold (0.02 log units) below it, and the stated range covers the measured number.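

In this assay, dimethylamino in place of ethylamino on a saturated chain carbon bound to a carbonyl carbon gives a 1.8-fold lower number from compound 2 to compound 4 (0.25 log units; within the scatter), and the change reads much the same on both cores: the same change on two cores in this assay, a 1.9-fold lower number (0.29 log units; within the scatter) from compound 1 to compound 3 and a 1.8-fold lower number (0.25 log units; within the scatter) from compound 2 to compound 4, 1.1-fold (0.04 log units) apart, within the scatter of two such steps. Within these two pairs, then, the change carries from the core of compound 1 to the core of compound 2 with no visible difference in the size of the step. Each step on its own stays within the scatter, however, and the agreement rests on just two small steps; it does not establish that the change moves the number at all, nor that it would behave the same way on any further core.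

The compounds shown leave open how the two cores would respond to a larger change at the end of the side chain, such as a cyclic amine like pyrrolidine or morpholine, an unsubstituted amine, a carboxylic acid, or a longer chain carrying the amine. They also leave open whether a step clearly beyond the scatter on one core would carry over to the other in the same way.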